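The source may report more compounds than this note shows. Statements on the series, on what has been measured and on what is new or still open speak of the compounds shown alone.

Measured so far in an assay on microsomes from intestine for inhibition of acyl-CoA:cholesterol acyltransferase (Oryctolagus cuniculus); on this read-out lower numbers stand for stronger inhibition and higher numbers for weaker inhibition:
- compound 1 `CCCCN1NN=C(NC(=O)Nc2c(C(C)C)cccc2C(C)C)N1`: compound 1 gives 92 nM
- compound 2 `CCCCCCCCN1NN=C(NC(=O)Nc2c(C(C)C)cccc2C(C)C)N1`: compound 2 gives 59 nM
- compound 3 `CCCCCCCCCCCN1NN=C(NC(=O)Nc2c(C(C)C)cccc2C(C)C)N1`: compound 3 gives 9 nM

Compound 3 holds the lowest number of the three in this assay; the nearer of the two other numbers stands at a 6.6-fold lower number from compound 2 to compound 3 (0.82 log units; beyond the scatter), and the further one at a 10-fold lower number from compound 1 to compound 3 (1.01 log units; beyond the scatter), both beyond the scatter.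

The next compound, compound 4 `CCCCCCCCCCCCN1NN=C(NC(=O)Nc2c(C(C)C)cccc2C(C)C)N1`, differs from compound 3 by methyl in place of hydrogen on a saturated chain carbon, ten or more bonds along the chain from an amine nitrogen in a ring. Going by the values given here, the steps that bear on it are the chain extensions: a 1.6-fold lower number from compound 1 to compound 2 (0.19 log units; within the scatter) stayed within the scatter, whereas a 6.6-fold lower number from compound 2 to compound 3 (0.82 log units; beyond the scatter) and a 10-fold lower number from compound 1 to compound 3 (1.01 log units; beyond the scatter) both lowered the number clearly. Among the compounds with values here, the change from compound 3 to compound 4 is the smallest extension yet, a single carbon, and no step of that size is on hand, so the direction is read off the longer extensions while the size is scaled down.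

Compound 4 is therefore expected to come in at or a little below compound 3, with the step of a 1.5-fold lower number from compound 3 to compound 4 (0.18 log units; within the scatter) likely inside the scatter. The estimate for compound 4 in this assay is 6 nM, with a range of 2.5 nM to 15 nM.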

Compound 4, half-maximal inhibitory concentration: 14 nM
Estimate against measurement, compound 4: 2.3-fold (0.37 log units) below; low and high end bracket the measured number.
By their numbers in this assay, from the lowest: compounds 3 and 4 (each within the scatter of the next); then compounds 2 and 1 (each within the scatter of the next).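

In this assay, methyl in place of hydrogen on a saturated chain carbon, ten or more bonds along the chain from an amine nitrogen in a ring, gives a 1.6-fold higher number from compound 3 to compound 4 (0.19 log units; within the scatter), so the clear lowering seen on reaching compound 3 cannot be read as continuing at this chain length; the other step within the scatter in the series lies at the short end, from compound 1 to compound 2. The advantage over the shorter chains nevertheless survives at compound 4, with a 4.2-fold lower number from compound 2 to compound 4 (0.62 log units; beyond the scatter) and a 6.6-fold lower number from compound 1 to compound 4 (0.82 log units; beyond the scatter), so the long-chain pair of compound 3 and compound 4 stands apart from compound 1 and compound 2. Nothing measured on hand accounts for this flattening at the long end of the series.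

Going by these compounds, whether a longer chain than that of compound 4 would hold the number, raise it or lower it remains open. Also open, on these data alone, is whether a chain carrying an amine or a carboxylic acid, or a branched chain of similar length, would keep the number seen with the unbranched chains.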